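Halogen position on the pendant phenyl ring

This account rests on a few compounds, and the source may have more. Where it says the series, first, only, none or still open, it means among the compounds named here.

Compound 1, `Cn1c(=O)c2c(nc(CCSc3cccc(Br)c3)n2C)n(C)c1=O`: 372000 nM
Compound 2, `Cn1c(=O)c2c(nc(CCSc3cccc(Cl)c3)n2C)n(C)c1=O`: "not active" (no number reported)
Compound 3, `Cn1c(=O)c2c(nc(CCSc3ccc(Br)cc3)n2C)n(C)c1=O`: not yet measured

In an in vitro assay on cells for inhibition of Amine oxidase [flavin-containing] A (Homo sapiens), read by coupled enzyme assay, with a stated time of 20 min (a lower number here means a stronger inhibitor, a higher number a weaker inhibitor), compound 1 gives 372000 nM, a very weak result. Compound 2 is reported only as "not active" (no number reported), so no single number stands for compound 2; it sits at the inactive end of this assay, and the two measured compounds together show nothing better than very weak inhibition from this series.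

Compound 3 differs from compound 2 by 4-bromophenyl in place of 3-chlorophenyl on a sulfur. Within the data shown here, no step between two measured compounds is available to calibrate such a change, so the size and direction of the step from compound 2 to compound 3 cannot be read from the data. Given that compound 1 reads 372000 nM and compound 2 reads "not active" (no number reported), any shift is expected to remain within the very weak range rather than produce a potent inhibitor. Compound 3 is therefore expected to give roughly 300000 nM in this assay, with a plausible range from 50000 nM to 2000000 nM, and a considerable chance that only an inactive result is reported.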

Compound 3, half-maximal inhibitory concentration: 117000 nM
Compound 3: middle estimate off by 2.6-fold (0.41 log units), on the high side; the measured number falls inside the stated range.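

In this assay, among these compounds, replacing 3-bromophenyl with 4-bromophenyl on a sulfur gives a 3.2-fold lower number from compound 1 to compound 3 (0.50 log units; beyond the scatter), the first step that can be read, and it lies beyond the usual scatter. It shows that the assay responds to where the bromine sits on the pendant phenyl ring, with the rest of the molecule unchanged, although compound 3, at 117000 nM, remains a very weak inhibitor and the step is modest. No measurement shown here accounts for this difference between the two bromine placements.

Compound 2 carries no number, so steps involving it cannot be read, and the effect of chlorine in place of bromine remains unmeasured in these data, as does any separation of that swap from the change in ring position. Also open, from the compounds shown here alone, is whether 4-chlorophenyl, 4-methoxyphenyl, or a longer chain on the sulfur would lower the number further or leave the series in the same very weak range, and whether any such group could bring inhibition out of that range at all.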